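Carbonyl substituent change in a tetrahydroisoquinoline series

A few compounds are considered here, and "the series" means these few. Any claim that something is new, unique, unknown or untested is made for them only; others in the source may bear on it.

Measured so far:
compound 1, `CCNC(=O)Nc1cccc2c1CN(C)CC2c1ccccc1`, > 80 mg/kg;
compound 2, `CN1Cc2c(NC(=O)OCc3ccccc3)cccc2C(c2ccccc2)C1`, 25 mg/kg.

Among the measured compounds shown here, compound 2 holds the only actual number obtained in a functional assay on the whole organism for inhibition of sodium-dependent dopamine transporter (Mus musculus); on this read-out higher numbers stand for an effect only at larger amounts of compound and lower numbers for an effect already at smaller amounts; the other result is a limit. In this assay compound 1 reaches only (the limit of > 80 mg/kg in this assay, at which 1 of the 2 values shown sits), a limit of the assay and not a number. For the measured compounds named here, the one measured step, an at least 3.2-fold lower number from compound 1 to compound 2 (0.50 log units; beyond the scatter), shows that the benzyloxy carbonyl compound gives a number where the ethylamino carbonyl compound gives none.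

Compound 3, `CC(C)NCC(=O)Nc1cccc2c1CN(C)CC2c1ccccc1`, has not yet been tested. It differs from compound 2 by (isopropylamino)methyl in place of benzyloxy on a carbonyl carbon. Going by the values given here, the only step that bears on this change is an at least 3.2-fold lower number from compound 1 to compound 2 (0.50 log units; beyond the scatter), in which exchanging the group on the carbonyl carbon moved the result from a limit to a number. Removing the benzyloxy again, for a group that carries no ring, is therefore expected to move the number in this assay upward, by a 2.4-fold higher number from compound 2 to compound 3 (0.38 log units; beyond the scatter), with a real chance that only a limit is reported. The estimate for compound 3 in this assay is 60 mg/kg, between 20 mg/kg and 200 mg/kg.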

Compound 3, dose for half-maximal effect: about 30 mg/kg
For compound 3 the middle estimate is 2.0-fold (0.30 log units) above the measured one; the measured number falls inside the stated range.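

In this assay, a ring on the carbonyl carbon is not needed to obtain a number: the step of a 1.2-fold higher number from compound 2 to compound 3 (0.08 log units; within the scatter) lies within the scatter, so (isopropylamino)methyl, which has no ring, and benzyloxy cannot be told apart here. The earlier pair alone could have been read as a gain tied to the ring of benzyloxy, but an at least 2.6-fold lower number from compound 1 to compound 3 (0.42 log units; beyond the scatter) shows that a group without a ring also gives a number where ethylamino on the same carbonyl carbon does not. Compound 1 therefore stands alone in this small set as a limit of the assay and not a number: the limit of > 80 mg/kg in this assay, at which 1 of the 3 values shown sits.

The compounds shown do not settle what separates ethylamino from the other two groups, since (isopropylamino)methyl and benzyloxy share neither a ring nor a nitrogen and still give values within the scatter of each other. On these data alone, whether a carboxylic acid in place of the amine of (isopropylamino)methyl, or a longer chain ending in a dimethylamine, would still give a number in this assay remains open.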